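A few compounds are considered here, and "the series" means these few. Any claim that something is new, unique, unknown or untested is made for them only; others in the source may bear on it.

Of the compounds shown here, two sharing a common core have been measured in a functional assay on A549 cells (Homo sapiens) for antiproliferative activity, read by CCK-8 assay, with a stated time of 72 h; a lower number here means a stronger inhibitor of growth, a higher number a weaker inhibitor of growth. Compound 1, `CCCNS(=O)(=O)c1ccc(Nc2ncc3c(n2)N(C2CCCC2)[C@H](CC)C(=O)N3C)cc1`, gives 563 nM in this assay. Compound 2, `CC[C@@H]1C(=O)N(C)c2cnc(-n3ccc4cc(C(N)=O)ccc43)nc2N1C1CCCC1`, gives 4350 nM in this assay. Compound 1 thus stands at the lowest of the two numbers, and the gap between it and compound 2 lies beyond the usual scatter of repeated measurements.

Compound 3, `CC[C@@H]1C(=O)N(C)c2cnc(Nc3ccc(S(=O)(=O)NCC(C)C)cc3)nc2N1C1CCCC1`, has not yet been measured. It differs from compound 1 by methyl in place of hydrogen on a saturated chain carbon bound to two saturated chain carbons. Among the measured compounds shown here, no pair of measured compounds differing in just one place is available here, so the size of such a step cannot be read from earlier data. A change as modest as methyl in place of hydrogen on a saturated chain carbon would usually be expected to leave this assay roughly unchanged, with no step beyond the scatter in either direction.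

Compound 3 is therefore expected to give about 550 nM in this assay, within an estimated range from 220 nM to 1400 nM. This estimate means an expected step of a 1.0-fold lower number from compound 1 to compound 3 (0.01 log units; within the scatter), that is, little change.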

Compound 3, concentration for 50% growth inhibition: 750 nM
Compound 3: middle estimate off by 1.4-fold (0.13 log units), on the low side; measured number inside the range.
By their numbers in this assay, from the lowest: compounds 1 and 3 (each within the scatter of the next); then compound 2.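

In this assay, going from propylamino to isobutylamino gives a 1.3-fold higher number from compound 1 to compound 3 (0.12 log units; within the scatter). Among the compounds shown here, this is the first step here that can be read between compounds differing in one place, and it shows that methyl in place of hydrogen on a saturated chain carbon bound to two saturated chain carbons produces no difference that repeated measurements could separate. For the compounds shown here, it is only one step, so it speaks for this single added methyl on this chain, and no information from outside these numbers bears on the result.

The compounds shown leave open how far this end of the molecule can be altered: a longer chain such as pentyl, a cyclopropylmethyl group, or a chain ending in an amine or a carboxylic acid could each give a number close to that of compound 1 or far from it. They also leave open whether the same methyl would give a similarly small step on a chain of another length or on a different core.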